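A few compounds are considered here, and "the series" means these few. Any claim that something is new, unique, unknown or untested is made for them only; others in the source may bear on it.

In a functional assay on KB cells (Homo sapiens) for antiproliferative activity, read by sulforhodamine B assay, with a stated time of 72 h (a lower number here means a stronger inhibitor, a higher number a weaker inhibitor), compound 1 `O=C(/C=C/c1csc2ccccc12)c1ccccc1O` gives 6200 nM while compound 2 `O=C(/C=C/c1csc2ccccc12)c1cc(F)ccc1O` gives 7400 nM and compound 3 `O=C(/C=C/c1csc2ccccc12)c1cc(Br)ccc1O` gives 760 nM as the lowest of the three numbers. Compound 4 `Cc1ccc(O)c(C(=O)/C=C/c2csc3ccccc23)c1` has not yet been measured. It differs from compound 3 by one change methyl in place of bromo on an aromatic carbon and this change sits para to a hydroxy group. Bromo in place of hydrogen gave an 8.2-fold lower number from compound 1 to compound 3 (0.91 log units; beyond the scatter) and bromo in place of fluoro gave a 9.7-fold lower number from compound 2 to compound 3 (0.99 log units; beyond the scatter) whereas fluoro in place of hydrogen gave only a 1.2-fold higher number from compound 1 to compound 2 (0.08 log units; within the scatter) here. Among the measured compounds shown here, no methyl compound has been measured, so part of the drop seen with bromo is expected to be lost in this assay when methyl replaces it. The estimated step is a 2.4-fold higher number from compound 3 to compound 4 (0.37 log units; beyond the scatter) with considerable uncertainty. The estimate for compound 4 is 1800 nM with an expected range from 600 nM to 5500 nM in repeated measurements.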

Compound 4, half-maximal inhibitory concentration: 4900 nM
For compound 4 the middle estimate is 2.7-fold (0.43 log units) below the measured one, within the range that was stated.
By their numbers in this assay, from the lowest: compound 3; then compounds 4, 1 and 2 (each within the scatter of the next).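

In this assay the gain from bromo para to a hydroxy group does not carry over to methyl, with a 6.4-fold higher number from compound 3 to compound 4 (0.81 log units; beyond the scatter). Methyl instead falls in with hydrogen and fluoro, showing a 1.3-fold lower number from compound 1 to compound 4 (0.10 log units; within the scatter) and a 1.5-fold lower number from compound 2 to compound 4 (0.18 log units; within the scatter), so among these four groups only bromo in compound 3 stands apart. No measurement given here accounts for what sets bromo apart. Still open, from the compounds shown here alone, is whether chloro or iodo at this place would behave like bromo. How an amine or a longer chain would fare here is open as well.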